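Notes on a fluoro-for-methoxy step in a small series

The source may report more compounds than this note shows. Statements on the series, on what has been measured and on what is new or still open speak of the compounds shown alone.

Measured so far, in a functional assay on NCI-H522 cells (Homo sapiens) for inhibition, read by sulforhodamine B assay, with a stated time of 48 h, tested at 10 uM; on this read-out higher numbers stand for more inhibition at the one concentration tested (going by the name of the read-out) and lower numbers for less inhibition:
compound 1, `c1ccc(-c2cn3ccnc3c(-c3ccc4ncn(C5CCCCC5)c4c3)n2)cc1`: compound 1 gives 58.1%
compound 2, `COc1ccc(-c2cn3ccnc3c(-c3ccc4ncn(C5CCCCC5)c4c3)n2)cc1`: compound 2 gives -20.9%
compound 3, `COc1ccccc1-c1cn2ccnc2c(-c2ccc3ncn(C4CCCCC4)c3c2)n1`: compound 3 gives 22.2%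

Compound 3 stands second highest of the three in this assay; compound 1 lies above it by a number 35.9 percentage points lower from compound 1 to compound 3 (beyond the scatter) and compound 2 below it by a number 43.1 percentage points higher from compound 2 to compound 3 (beyond the scatter), both gaps beyond the scatter. Both methoxy placements on the phenyl ring lowered the read-out against compound 1: a number 79 percentage points lower from compound 1 to compound 2 (beyond the scatter) and a number 35.9 percentage points lower from compound 1 to compound 3 (beyond the scatter).

Compound 4, `Fc1ccccc1-c1cn2ccnc2c(-c2ccc3ncn(C4CCCCC4)c3c2)n1`, differs from compound 3 by fluoro in place of methoxy on an aromatic carbon. Going by the values given here, no measured step exchanges a methoxy for a fluoro, so the bearing of the earlier steps is indirect: they show only that the 2-methoxyphenyl compound sits between the bare phenyl compound and the 4-methoxyphenyl compound. A modest rise toward compound 1 is expected, a number 9.8 percentage points higher from compound 3 to compound 4 (within the scatter), with a broad range. Compound 4 is therefore estimated at 32%, between 5% and 60%.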

Compound 4, a percentage reported as inhibition, at one concentration (the size of the read-out at that concentration, not a potency): 17.8%
The estimate for compound 4 lay 14.2 percentage points above the measured number, within the range that was stated.
By their numbers in this assay, from the lowest: compound 2; then compounds 4 and 3 (each within the scatter of the next); then compound 1.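

In this assay the exchange of methoxy for fluoro on this aromatic carbon, ortho to a large group, gives a number 4.4 percentage points lower from compound 3 to compound 4 (within the scatter) and so does not separate the two groups at this position. Fluoro in place of hydrogen gives a number 40.3 percentage points lower from compound 1 to compound 4 (beyond the scatter) and so, like methoxy, it stands well apart from the unsubstituted phenyl of compound 1, which shows that this drop does not depend on methoxy alone. The change from 4-methoxyphenyl to 2-fluorophenyl gives a number 38.7 percentage points higher from compound 2 to compound 4 (beyond the scatter) and keeps the 2-fluorophenyl compound clearly apart from the 4-methoxyphenyl compound, as the 2-methoxyphenyl compound already was.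

From the compounds shown here alone, whether an amine, a hydroxyl or a longer alkoxy chain at this position would read with compound 1 or with compound 3 and compound 4 stays open. No evidence shown speaks to why fluoro and methoxy read alike here, or why either differs from hydrogen.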